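The source may report more compounds than this note shows. Statements on the series, on what has been measured and on what is new or still open speak of the compounds shown alone.

Values measured so far, all in a functional assay on A549 cells (Homo sapiens) for inhibition, read by MTT assay, with a stated time of 72 h; a higher number here means a weaker inhibitor, a lower number a stronger inhibitor:
- compound 1 `COc1cc2c(Oc3ccc(NC(=O)c4nn(-c5ccc(C)cc5C)cc(C)c4=O)cc3)ccnc2cc1OCCCCCCC(=O)NO`: 1840 nM
- compound 2 `COc1cc2c(Oc3ccc(NC(=O)c4nn(-c5ccccc5C)cc(C)c4=O)cc3)ccnc2cc1OCCCCCC(=O)NO`: 1820 nM
- compound 3 `COc1cc2c(Oc3ccc(NC(=O)c4nn(-c5ccc(C)cc5)cc(C)c4=O)cc3)ccnc2cc1OCCCCCCC(=O)NO`: 160 nM

Compound 3 has the lowest number of the three, while compound 1 and compound 2 lie within the scatter of each other. The next structure is compound 4 `COc1cc2c(Oc3ccc(NC(=O)c4nn(-c5ccccc5C)cc(C)c4=O)cc3)ccnc2cc1OCCCCCCC(=O)NO`, which has the same atoms as compound 3 joined differently: 2-methylphenyl in place of 4-methylphenyl on an aromatic nitrogen.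

For the measured compounds named here, the one measured step that bears on this change is a 12-fold lower number from compound 1 to compound 3 (1.06 log units; beyond the scatter), a large one that removes a methyl from the aryl group of compound 1 and leaves the 4-methylphenyl of compound 3. Compound 2 carries the same 2-methylphenyl as compound 4 on a different chain, and compound 2 gives 1820 nM in this assay. Going by the values given here, no measured pair isolates the chain, so that value is only a loose guide.

A large step towards a higher number is therefore expected, with a 6.3-fold higher number from compound 3 to compound 4 (0.80 log units; beyond the scatter) as the estimate. The estimated value for compound 4 is 1000 nM (320 nM to 2800 nM).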

Compound 4, half-maximal inhibitory concentration: 3130 nM
Compound 4: middle estimate off by 3.1-fold (0.50 log units), on the low side; the measured number lies above the stated range.
By their numbers in this assay, from the lowest: compound 3; then compounds 2, 1 and 4 (each within the scatter of the next).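

In this assay, moving the single methyl from 4-methylphenyl to 2-methylphenyl on the aromatic nitrogen gives a 20-fold higher number from compound 3 to compound 4 (1.29 log units; beyond the scatter), so the placement of this methyl alone, with the atoms unchanged, accounts for a large step. Once the 2-methylphenyl arrangement is present, neighbouring changes matter little: removing the other aryl methyl gives a 1.7-fold higher number from compound 1 to compound 4 (0.23 log units; within the scatter) and changing the chain gives a 1.7-fold higher number from compound 2 to compound 4 (0.24 log units; within the scatter), both within the scatter. Nothing available here gives a reason for the large step.

As far as these compounds go, it remains open whether the 4-methylphenyl group keeps its advantage on the chain of compound 2 or on a longer chain. An unsubstituted phenyl or a 4-chlorophenyl on the aromatic nitrogen would show whether the 4-methyl group itself matters or the 2-methyl group is the sole cost.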